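Fluoro for trifluoromethyl on two cores: microsomal stability

A few compounds are considered here, and "the series" means these few. Any claim that something is new, unique, unknown or untested is made for them only; others in the source may bear on it.

Compound 1 `CCC(c1nc2ncc(Cl)cc2[nH]1)[C@H]1CC[C@@H](c2ccnc3ccc(C(F)(F)F)cc32)CC1` gives 81% in an ADME assay on microsomes from liver (Rattus norvegicus) for metabolic stability, with a stated time of 10 min, tested at 0.5 uM; on this read-out higher numbers stand for a more stable compound and lower numbers for a less stable compound. Compound 2 `CCC(Nc1nnc(-c2ccc(OC)cc2)o1)[C@H]1CC[C@@H](c2ccnc3ccc(C(F)(F)F)cc32)CC1`, built on a different core, gives 100% in this assay; the difference between the two cores is not broken down here. Compound 3 `CCC(c1nc2ncc(Cl)cc2[nH]1)[C@H]1CC[C@@H](c2ccnc3ccc(F)cc32)CC1` carries fluoro in place of trifluoromethyl on an aromatic carbon and gives 35% in this assay, so that a number 46 percentage points lower from compound 1 to compound 3 (beyond the scatter). Compound 4 `CCC(Nc1nnc(-c2ccc(OC)cc2)o1)[C@H]1CC[C@@H](c2ccnc3ccc(F)cc32)CC1`, not yet measured, carries fluoro in place of trifluoromethyl on an aromatic carbon, the same change made on the core of compound 2. Beside a number 46 percentage points lower from compound 1 to compound 3 (beyond the scatter), the expected step is a number 38 percentage points lower from compound 2 to compound 4 (beyond the scatter), a drop of similar kind but somewhat smaller, because compound 2 starts from 100% and the read-out cannot rise above full recovery. Compound 4 is therefore estimated at 62% in this assay, with a range from 35% to 88%; this rests on a single measured pair, compound 1 and compound 3.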

Compound 4, percent of the compound remaining: 45%
Beside the measured number, compound 4's estimate is 17 percentage points above it, within the range that was stated.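

In this assay, fluoro in place of trifluoromethyl on an aromatic carbon again gives a large drop, a number 55 percentage points lower from compound 2 to compound 4 (beyond the scatter). Set beside the earlier pair, the change carries over from one core to the other with no difference beyond the scatter: the same change on two cores in this assay, a number 46 percentage points lower (beyond the scatter) from compound 1 to compound 3 and a number 55 percentage points lower (beyond the scatter) from compound 2 to compound 4, 9 percentage points apart, within the scatter of two such steps This rests on only two pairs, and it does not show how the change behaves on a third core or which part of these compounds accounts for the loss.

The compounds shown leave open how a nitrile or a methyl on that aromatic carbon stands in this assay. Also open, on these data alone, is whether an amine on the same carbon keeps the stability seen with trifluoromethyl on either core.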